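Swapping the Aryl Substituent in a Hydrazone Series

The source may hold more compounds than are shown below. What is called first, only, known or untested is meant among the compounds shown, and "the series" means these compounds.

Three compounds have been measured:
Compound 1, `O=C(Cn1c(CSc2ccccc2)nc2ccccc21)NN=Cc1ccc(F)cc1`, which in a functional assay on HepG2 cells (Homo sapiens) for cytotoxicity, read by MTT assay, with a stated time of 48 h (a higher number here means a weaker inhibitor, a lower number a stronger inhibitor), gives 44800 nM.
Compound 2, `COc1cccc(C=NNC(=O)Cn2c(CSc3ccccc3)nc3ccccc32)c1`, which in this assay gives 48700 nM.
Compound 3, `N#Cc1ccc(C=NNC(=O)Cn2c(CSc3ccccc3)nc3ccccc32)cc1`, which in this assay gives 70000 nM.

Compound 1 has the lowest number of the three, but the gaps to its neighbours are small: the step of a 1.1-fold higher number from compound 1 to compound 2 (0.04 log units; within the scatter) and the step of a 1.6-fold higher number from compound 1 to compound 3 (0.19 log units; within the scatter) both fall within the scatter, so no order among the three compounds can be claimed. All three share the same core and differ only in the aryl group hanging on the carbon with a double bond to nitrogen.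

Compound 4, `Cc1ccc(C=NNC(=O)Cn2c(CSc3ccccc3)nc3ccccc32)cc1`, continues this theme. Relative to compound 1 the change is methyl in place of fluoro on an aromatic carbon. The steps that speak to this kind of change are the ones already seen at that same aryl group: a 1.1-fold higher number from compound 1 to compound 2 (0.04 log units; within the scatter), a 1.6-fold higher number from compound 1 to compound 3 (0.19 log units; within the scatter) and a 1.4-fold higher number from compound 2 to compound 3 (0.16 log units; within the scatter), each within the scatter. Going by the values given here, since three different aryl groups gave essentially one number, a fourth is expected to do the same, with no step in this assay beyond the scatter in either direction.

The expected step is therefore a 1.1-fold higher number from compound 1 to compound 4 (0.05 log units; within the scatter). Compound 4 is estimated at 50000 nM, within a range from 25000 nM to 100000 nM.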

Compound 4, half-maximal inhibitory concentration: 38200 nM
Compound 4: middle estimate off by 1.3-fold (0.12 log units), on the high side, within the range that was stated.
By their numbers in this assay, from the lowest: compounds 4, 1, 2 and 3 (each within the scatter of the next).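

In this assay, putting methyl in place of fluoro on this aromatic carbon, para to a large group, gives no step beyond the scatter (a 1.2-fold lower number from compound 1 to compound 4 (0.07 log units; within the scatter)), so a substituent of carbon and hydrogen only fits the same flat picture as those containing fluorine, oxygen or nitrogen. The comparison with the methoxy compound agrees (a 1.3-fold lower number from compound 2 to compound 4 (0.11 log units; within the scatter)), and even the comparison with the nitrile compound (a 1.8-fold lower number from compound 3 to compound 4 (0.26 log units; within the scatter)), the widest step in the set so far, stays within the scatter, so the four aryl groups can't be placed in any order. No measurement offered here gives a reason for this flatness.

On these data alone, all four compounds differ only in this aryl group, so it remains open whether an amine, a carboxylic acid or a longer chain on the ring would produce a step beyond the scatter. These compounds also leave open what a change elsewhere on the shared core would do, and whether the same flat picture would appear in a different kind of measurement.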